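Fluoro replaces methylcarbamoyl on the shared core

The source may report more compounds than this note shows. Statements on the series, on what has been measured and on what is new or still open speak of the compounds shown alone.

In an ADME assay on microsomes from liver (Homo sapiens) for metabolic stability, using NADPH, with a stated time of 40 min, tested at 2 uM (a lower number here means that the compound disappears faster, a higher number that the compound lasts longer), compound 3 `CNC(=O)c1cccc2nc(-c3c[nH]c4c(C)cccc34)ccc12` gives 0.983 h as its half-life, the second highest of three numbers. Compound 2 `Cc1cccc2c(-c3ccc4cccc(Br)c4n3)c[nH]c12` stands higher at 2.4 h as its half-life, and compound 1 `Cc1cccc2c(-c3ccc4c(O)cccc4n3)c[nH]c12` stands lower at 0.283 h on the same measure. Compound 4 `Cc1cccc2c(-c3ccc4c(F)cccc4n3)c[nH]c12` has fluoro in place of methylcarbamoyl on an aromatic carbon. Among the compounds with values here, the one measured step at this carbon (a 3.5-fold higher number from compound 1 to compound 3 (0.54 log units; beyond the scatter)) is modest and involves no fluoro group, so it offers only weak guidance. In this assay the expected step (a 1.4-fold higher number from compound 3 to compound 4 (0.15 log units; within the scatter)) is therefore small and upward, an estimate that stays within the usual scatter. Compound 4 is expected to show a half-life of about 1.4 h, with an estimated range from 0.55 h to 3.5 h in this measure.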

Compound 4, half-life: 0.217 h
Beside the measured number, compound 4's estimate is 6.5-fold (0.81 log units) above it, and the stated range ends above it.
By their numbers in this assay, from the lowest: compounds 4 and 1 (each within the scatter of the next); then compound 3; then compound 2.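

Fluoro in place of methylcarbamoyl on this aromatic carbon shortens the half-life in this assay (a 4.5-fold lower number from compound 3 to compound 4 (0.66 log units; beyond the scatter)), so the longer-lasting compound 3 is not matched by this smaller group. Fluoro and hydroxy cannot be told apart at this carbon (a 1.3-fold lower number from compound 1 to compound 4 (0.12 log units; within the scatter)), which leaves methylcarbamoyl as the one group of the three that stands apart here. Nothing measured here explains this difference.

Still open, going by these compounds, is how an amine or a carboxylic acid on this carbon would compare. Also open, on these data alone, is whether a longer chain on the amide nitrogen would extend the half-life further.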